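The source may hold more compounds than are shown below. What is called first, only, known or untested is meant among the compounds shown, and "the series" means these compounds.

Compound 3 `COc1cccc(C(=O)CC2C(C#N)=C(N)Oc3c(OC)cc(Br)cc32)c1` gives 32.3% in an ADME assay on MCF-10A cells (Homo sapiens) for cytotoxicity, read by sulforhodamine B assay, with a stated time of 72 h, tested at 10 uM (a lower number here means a weaker effect, a higher number a stronger effect of the compound at the concentration tested), the lowest of the three numbers measured, set against compound 2 `COc1cc(Br)cc2c1OC(N)=C(C#N)C2CC(=O)c1ccc(Cl)cc1` with 36.8% and compound 1 `COc1cc(Br)cc2c1OC(N)=C(C#N)C2CC(=O)c1ccccc1` with 45.9%. Compound 4 `COc1cccc(C(=O)CC2C(C#N)=C(N)Oc3ccc(Br)cc32)c1` has not been measured yet; it differs from compound 3 by hydrogen in place of methoxy on an aromatic carbon. Going by the values given here, none of the measured steps touches this place in the molecule. The closest guide is a number 13.6 percentage points lower from compound 1 to compound 3 (beyond the scatter), where methoxy entered on an aromatic carbon elsewhere in the molecule, while a number 4.5 percentage points lower from compound 2 to compound 3 (within the scatter) stayed within the scatter. Taking the methoxy away again in compound 4 is therefore expected to give at most a small step, a number 3.7 percentage points higher from compound 3 to compound 4 (within the scatter). Compound 4 is estimated at 36%, with a range from 22% to 50%.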

Compound 4, a percentage reported as activity, at one concentration (the size of the read-out at that concentration, not a potency): 101%
Compound 4: the middle estimate sits 65 percentage points below what was measured; the whole stated range lies below it.
By their numbers in this assay, from the lowest: compounds 3, 2 and 1 (each within the scatter of the next, the first and the last beyond it); then compound 4.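

In this assay, taking away the methoxy on the aromatic carbon ortho to a fused ring gives a number 68.7 percentage points higher from compound 3 to compound 4 (beyond the scatter). Going by these compounds alone, this single position therefore matters far more for the read-out than the places changed in the earlier steps. A loss of only two heavy atoms is enough to produce this large step, but no measurement here explains it.

Going by these compounds, it remains open whether an ethoxy, a fluoro or an amine at this carbon would keep the high number. On these data alone, it is also open whether removing the methoxy from compound 2, with its 4-chlorophenyl group, would give a similar rise.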